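The source may hold more compounds than are shown below. What is called first, only, known or untested is meant among the compounds shown, and "the series" means these compounds.

In a functional assay on CWR22R cells (Homo sapiens) for antiproliferative activity, read by propidium iodide staining, with a stated time of 96 h (on this read-out higher numbers stand for weaker inhibition and lower numbers for stronger inhibition), compound 1 `CC(O)(CSc1cccc(S(F)(F)(F)(F)F)c1)C(=O)Nc1cccc(S(F)(F)(F)(F)F)c1` gives 17200 nM, compound 2 `CC(O)(CSc1ccc(F)cc1)C(=O)Nc1cccc(S(F)(F)(F)(F)F)c1` gives 30200 nM, and compound 3 `CC(O)(CSc1cccc(C(F)(F)F)c1)C(=O)Nc1cccc(S(F)(F)(F)(F)F)c1` gives 12900 nM. Compound 3 therefore stands level with compound 1 and clearly under compound 2. Compound 4 `CC(O)(CSc1cccc(OC(F)(F)F)c1)C(=O)Nc1cccc(S(F)(F)(F)(F)F)c1` differs from compound 3 in one place, with trifluoromethoxy in place of trifluoromethyl on an aromatic carbon. For the measured compounds named here, no measured step tests trifluoromethoxy itself. The closest evidence is a different exchange at that same place, which gave a 1.3-fold lower number from compound 1 to compound 3 (0.12 log units; within the scatter). The larger 2.3-fold lower number from compound 2 to compound 3 (0.37 log units; beyond the scatter) involved a wider change, from one substituted phenyl to another. No shift beyond the scatter is therefore expected in this assay, and the expected step is a 1.0-fold higher number from compound 3 to compound 4 (0.00 log units; within the scatter). The estimate for compound 4 is 13000 nM, with a range from 7000 nM to 24000 nM.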

Compound 4, half-maximal inhibitory concentration: 18700 nM
Beside the measured number, compound 4's estimate is 1.4-fold (0.16 log units) below it, and the stated range covers the measured number.
By their numbers in this assay, from the lowest: compounds 3, 1, 4 and 2 (each within the scatter of the next, the first and the last beyond it).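

In this assay, this place on the aromatic ring accepts an oxygen link to the trifluoromethyl group with only a small change, a 1.4-fold higher number from compound 3 to compound 4 (0.16 log units; within the scatter). Replacing the sulfur-and-fluorine group of compound 1 with trifluoromethoxy gives a 1.1-fold higher number from compound 1 to compound 4 (0.04 log units; within the scatter), so all three fluorinated groups tested here lie within the scatter of one another. Nothing available explains this tolerance. The compounds shown leave open whether a group without fluorine, such as an amine or a carboxylic acid, would shift the number beyond the scatter at this place.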